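A few compounds are considered here, and "the series" means these few. Any claim that something is new, unique, unknown or untested is made for them only; others in the source may bear on it.

For the measured compounds named here, compound 1 `COc1ccc(-c2nc(CN(C)C)sc2-c2ccc(OC)cc2)cc1` is the only member of the series with a number in a functional assay with Oryctolagus cuniculus as the target (on this read-out lower numbers stand for stronger inhibition and higher numbers for weaker inhibition), where compound 1 gives 96 nM. Compound 2 `COc1ccc(-c2nc(C(=O)N3CCNC(CCO)C3)sc2-c2ccc(OC)cc2)cc1` appears in this assay only as a limit, > 1000 nM, which is the limit of > 1000 nM in this assay, at which 1 of the 2 values shown sits. Compound 3 `COc1ccc(-c2nc(/C=C/C(=O)O)sc2-c2ccc(OC)cc2)cc1` differs from compound 1 by 2-carboxyethenyl in place of (dimethylamino)methyl on an aromatic carbon. Going by the values given here, no measured step in this assay covers a change of this kind, so only an expectation can be set. A loss beyond the usual scatter is expected, estimated as a 6.3-fold higher number from compound 1 to compound 3 (0.80 log units; beyond the scatter). Compound 3 is accordingly expected to give about 600 nM, in a range from 150 nM to 3000 nM.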

Compound 3, half-maximal inhibitory concentration: > 100 nM
Compound 3 was reported as a limit; the forecaster's own chance of this, stated with the estimate: 35%; the middle value lies beyond the limit too.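

In this assay, 2-carboxyethenyl in place of (dimethylamino)methyl on this aromatic carbon gives an at least 1.0-fold higher number from compound 1 to compound 3 (0.01 log units; that floor lies within the scatter). This sets only a floor for the change, so neither a real loss nor a match with the dimethylamino compound is established. The entry for compound 3 is a limit, not a number: the limit of > 100 nM in this assay, at which 1 of the 3 values shown sits.

As far as these compounds go, the true size of this step remains open. Also open, from the compounds shown here alone, is whether a carboxylic acid attached directly to the ring, or a longer amine such as 2-(dimethylamino)ethyl, would read differently at this position.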